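Series notes: a new ring substituent for compound 3

The source may report more compounds than this note shows. Statements on the series, on what has been measured and on what is new or still open speak of the compounds shown alone.

Measured compounds in an assay on CHO cells for displacement of a labelled ligand from adenosine receptor A3 (Homo sapiens), read by scintillation counting, tested at 10 uM; on this read-out lower numbers stand for less inhibition and higher numbers for more inhibition at the one concentration tested (going by the name of the read-out):
compound 1 `CC(C)(C)Cc1csc(N)c1C(=O)c1ccc(Cl)cc1` — 5%
compound 2 `Cc1c(Br)sc(N)c1C(=O)c1ccc(Cl)cc1` — 1%
compound 3 `CC(C)(C)Cc1c(-c2ccccn2)sc(N)c1C(=O)c1ccc(Cl)cc1` — 1%

All three numbers sit at the low end of this assay. Compound 3 and compound 2 read the same at the digits shown, and the step of a number 4 percentage points lower from compound 1 to compound 3 (within the scatter) is within the scatter, so none of the three can be set apart from the others on the numbers in hand.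

The next compound, compound 4 `CC(C)(C)Cc1c(-c2cc(F)ccc2F)sc(N)c1C(=O)c1ccc(Cl)cc1`, differs from compound 3 by 2,5-difluorophenyl in place of pyridin-2-yl on an aromatic carbon.

For the measured compounds named here, only one measured step touches the same ring position: a number 4 percentage points lower from compound 1 to compound 3 (within the scatter), where a pyridin-2-yl entered in place of hydrogen and the read-out did not move beyond the scatter. Going by the values given here, no measured pair shows one aryl group exchanged for another at this position, and no measured pair shows a fluorine-bearing ring anywhere. Compound 2, which carries bromine at that position and a methyl group in place of neopentyl, also reads low. With every measured substituent at this position giving a low number, the step of a number 2 percentage points higher from compound 3 to compound 4 (within the scatter) is expected to stay within the scatter, with no direction favoured.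

Compound 4 is therefore estimated at 3%, within a range from 0% to 12%.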

Compound 4, a percentage reported as inhibition, at one concentration (the size of the read-out at that concentration, not a potency): 1%
Estimate against measurement, compound 4: 2 percentage points above, and the stated range covers the measured number.
By their numbers in this assay, from the lowest: compounds 2, 3, 4 and 1 (each within the scatter of the next).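

Working from this assay, replacing pyridin-2-yl with 2,5-difluorophenyl on the aromatic carbon next to the ring sulfur gives no change at the digits printed from compound 3 to compound 4 (within the scatter), and this is the first measured exchange of one aryl group for another at this position. The change removes the ring nitrogen and its hydrogen-bond acceptor and adds two fluorines, yet the read-out does not move beyond the scatter; measured against hydrogen at the same carbon, the 2,5-difluorophenyl group gives a number 4 percentage points lower from compound 1 to compound 4 (within the scatter), which matches the earlier result for pyridin-2-yl in staying within the scatter. No measurement in hand offers an explanation for this flat read-out at the position.

On these data alone, with all the numbers at the low end and read at a single concentration, these compounds show no substituent at this carbon that lifts the read-out, so the position's capacity to affect it remains unknown. As far as these compounds go, whether an aliphatic amine, a carboxylic acid or a longer alkyl chain at this carbon would read any differently stays open, as does the effect of replacing the neopentyl group while an aryl group is present here.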